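From Nitro to Iodo on an Aromatic Carbon

This account rests on a few compounds, and the source may have more. Where it says the series, first, only, none or still open, it means among the compounds named here.

Measured so far in a functional assay on U-87MG ATCC cells (Homo sapiens) for cytotoxicity, read by MTT assay, with a stated time of 48 h; a higher number here means a weaker inhibitor, a lower number a stronger inhibitor:
- Compound 1 `CC(=NNC(=S)Nc1cccc(I)c1)c1ccccn1`: 84 nM
- Compound 2 `C/C(=N/NC(=S)Nc1cccc([N+](=O)[O-])c1)c1ccccn1`: 69 nM

Among the compounds with values here, only these two compounds have numbers so far. Compound 2 gives 69 nM in this assay and stands level with compound 1 at 84 nM, since the two values lie within the scatter of each other.

The next compound to be tested is compound 3 `C/C(=N/NC(=S)Nc1cccc(I)c1)c1ccccn1`. It keeps the shared core of compound 2 and carries iodo in place of nitro on an aromatic carbon. Within the data shown here, no measured pair differing in one place shows the size of this change directly, so the evidence is limited. The closest guide is compound 1, which also carries iodo and gives 84 nM in this assay. On that basis, no step beyond the scatter is expected in this assay, and any drift would be expected toward a slightly higher number. The expected step is a 1.2-fold higher number from compound 2 to compound 3 (0.06 log units; within the scatter). For compound 3 the estimated value is 80 nM, with an expected range from 45 nM to 140 nM.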

Compound 3, half-maximal inhibitory concentration: 84 nM
The estimate for compound 3 lay 1.1-fold (0.02 log units) below the measured number; low and high end bracket the measured number.
By their numbers in this assay, from the lowest: compounds 2, 1 and 3 (each within the scatter of the next).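

In this assay, the exchange of nitro for iodo on an aromatic carbon, meta to a large group, can now be read from a pair that differs in this one place: the result is a 1.2-fold higher number from compound 2 to compound 3 (0.09 log units; within the scatter). At this position, then, the read-out does not separate nitro from iodo, although the two groups differ in size and in their counts of heavy atoms and hydrogen-bond acceptors. The second pair adds a separate point, no change at the digits printed from compound 1 to compound 3 (within the scatter), so a double bond drawn as Z in compound 3 and without a configuration in compound 1 goes with no visible difference in the number, and the comparison rests on a single feature: the fact that one of compounds 1 and 3 is drawn with a defined configuration and the other without, at the place where they differ.

The compounds shown leave open whether the level of these values would hold with quite different groups on this carbon, such as an amine, a carboxylic acid or a methoxy group. They also leave open what a double bond with the opposite drawn configuration would give, and whether compound 1 is a different material from compound 3 at all.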